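Compound 3 loses its aminomethyl end

A few compounds are considered here, and "the series" means these few. Any claim that something is new, unique, unknown or untested is made for them only; others in the source may bear on it.

Within the data shown here, in a functional assay on the whole organism for antagonist activity, with Mus musculus as the target (on this read-out higher numbers stand for an effect only at larger amounts of compound and lower numbers for an effect already at smaller amounts), compound 3 (`CC(NC(=O)CN)C(=O)N(C)c1ccc(Cl)cc1C(=O)c1ccccc1Cl`) reads 0.47 mg/kg and holds the lowest number of the three compounds measured so far. Compound 1 (`NCC(=O)NCC(=O)Nc1ccc([N+](=O)[O-])cc1C(=O)c1ccccc1Cl`) reads 2.64 mg/kg and compound 2 (`NC(C(=O)NCC(=O)Nc1ccc(Cl)cc1C(=O)c1ccccc1)c1ccccc1`) reads 28 mg/kg at the far end, and both lie beyond the scatter from compound 3. Compound 4 (`CC(C)C(=O)NCC(=O)N(C)c1ccc(Cl)cc1C(=O)c1ccccc1Cl`) carries ((isopropylcarbonyl)amino)methyl in place of 1-(((aminomethyl)carbonyl)amino)ethyl on a carbonyl carbon. Among the measured compounds shown here, all three measured compounds end in a free amino group, and compound 4 does not, so no measured compound shows this change directly. For the measured compounds named here, the only guide to how far the number can climb is compound 2 at 28 mg/kg in this small set. A large rise is therefore expected, with a 130-fold higher number from compound 3 to compound 4 (2.11 log units; beyond the scatter) estimated to lie well beyond the scatter, toward larger doses. Compound 4 is estimated at 60 mg/kg with 8 mg/kg to 300 mg/kg as its expected range, and the read-out may yield only a limit.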

Compound 4, dose for half-maximal effect: 6 mg/kg
The estimate for compound 4 lay 10-fold (1.00 log units) above the measured number, outside the stated range (below it).
By their numbers in this assay, from the lowest: compound 3; then compound 1; then compound 4; then compound 2.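

In this assay, among these compounds, the change on a carbonyl carbon whose other neighbours are amide-type nitrogen gives a 13-fold higher number from compound 3 to compound 4 (1.11 log units; beyond the scatter), the first step between compounds that differ in one place. The swap from 1-(((aminomethyl)carbonyl)amino)ethyl to ((isopropylcarbonyl)amino)methyl leaves the heavy-atom count unchanged, yet lowers the hydrogen-bond donor and acceptor counts, and compound 4 still gives a measured number, not a limit, without the free amino end. Nothing measured here accounts for the size of this step.

The step alters the branch and the chain end together, and the compounds shown do not separate the two. From the compounds shown here alone, how a dimethylamino group or a carboxylic acid in place of the isopropyl would read also remains open.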